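A Ring Swap on a Metabolically Stable Series

The compounds below may be only part of what the source reports. "The series", "measured", "known", "first", "only" and "open" are said of these compounds alone.

Values from an ADME assay on liver (Homo sapiens) for metabolic stability, using microsomes; on this read-out higher numbers stand for a longer-lived compound and lower numbers for a shorter-lived compound
- compound 1 `COc1cnc(O[C@@H]2C[C@@H](C(=O)N[C@]3(C(=O)NS(=O)(=O)C4CC4)C[C@H]3C3CC3)N(C(=O)[C@@H](NC(=O)OC(C)(C)C)C(C)(C)C)C2)c2cc(Cl)ccc12` gives 1.38 h
- compound 2 `COc1cnc(O[C@@H]2C[C@@H](C(=O)N[C@]3(C(=O)NS(=O)(=O)C4CC4)C[C@H]3C3CC3)N(C(=O)[C@@H](NC(=O)O[C@@H](C)C(F)(F)F)C(C)(C)C)C2)c2cc(Cl)ccc12` gives > 3.33 h as a limit of the assay, not a number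
- compound 3 `COc1cnc(O[C@@H]2C[C@@H](C(=O)N[C@]3(C(=O)NS(=O)(=O)C4CC4)C[C@H]3C3CC3)N(C(=O)[C@@H](NC(=O)O[C@H](C)C(F)(F)F)C(C)(C)C)C2)c2cc(Cl)ccc12` gives 2.12 h

Compound 3 stands level with compound 1 within the usual scatter (a 1.5-fold higher number from compound 1 to compound 3 (0.19 log units; within the scatter)), and compound 2 offers only its limit for comparison.

The change to compound 4 `COc1cnc(O[C@@H]2C[C@@H](C(=O)N[C@]3(C(=O)NS(=O)(=O)C4CC4)C[C@H]3C3CC3)N(C(=O)[C@@H](NC(=O)O[C@H](C)C(F)(F)F)C3CCC3)C2)c2cc(Cl)ccc12` is cyclobutyl in place of tert-butyl on a saturated chain carbon bound to an amide-type nitrogen and a carbonyl carbon. Among the compounds with values here, no measured step touches this place. All of them alter a different group, so they show only how far these compounds have moved so far: one step lies beyond the scatter (an at least 2.4-fold higher number from compound 1 to compound 2 (0.38 log units; beyond the scatter)), and another has a floor within it (an at least 1.5-fold lower number from compound 2 to compound 3 (0.19 log units; that floor lies within the scatter)).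

With no direct guide, no step beyond the scatter is expected in this assay in either direction, and the expectation stays close to compound 3 at 2.12 h with a wide range. The expected change is small (a 1.2-fold lower number from compound 3 to compound 4 (0.07 log units; within the scatter)). For compound 4 the estimated half-life is 1.8 h with an expected range from 0.8 h to 3.6 h in this measurement.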

Compound 4, half-life: 1.85 h
The estimate for compound 4 lay 1.0-fold (0.01 log units) below the measured number; the measured number falls inside the stated range.
By their numbers in this assay, from the lowest: compounds 1, 4 and 3 (each within the scatter of the next). At a limit, above all of these: compound 2.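

In this assay, the swap of cyclobutyl for tert-butyl on a saturated chain carbon bound to an amide-type nitrogen and a carbonyl carbon gives a 1.1-fold lower number from compound 3 to compound 4 (0.06 log units; within the scatter). Within the data shown here, none of the earlier steps touched this place, so this is the first reading of it: here a four-membered ring of carbon can stand in for the open tert-butyl group with no change beyond the usual scatter of repeat measurements. That reading rests on this one pair of compounds.

Going by these compounds, how cyclobutyl would behave on compound 2 stays open, as the value of compound 2 is a limit of the assay and not a number: the limit of > 3.33 h in this assay, at which 1 of the 4 values shown sits. Also open is what larger or different groups would do at this place, such as cyclohexyl, phenyl or an amine.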